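The compounds below may be only part of what the source reports. "The series", "measured", "known", "first", "only" and "open" are said of these compounds alone.

In a functional assay on the whole organism (strain albino) for inhibition, with Rattus norvegicus as the target, read by paw edema, with stated times of 1 h and 3 h, at a dose of 20 mmol/kg by the intraperitoneal route (on this read-out lower numbers stand for a weaker effect and higher numbers for a stronger effect at the one dose given), the three measured compounds gave these results:
compound 1 `N#CC1=C(NCC(=O)N2CCOCC2)N(c2ccccc2)C(=O)N2CCCCC(N3CCCC3)C12`: 73.5%
compound 2 `N#CC1=C(NCN2CCCCC2)N(c2ccccc2)C(=O)N2CCCCC(N3CCCC3)C12`: 42.1%
compound 3 `COc1ccc(/C=N/C2=C(C#N)C3C(N4CCCC4)CCCCN3C(=O)N2c2ccccc2)cc1`: 75.3%

Compound 3 has the highest number of the three. Compound 1 sits very close to it, within the scatter, so no order can be read between these two; compound 2 lies well below both.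

Compound 4 `N#CC1=C(N)N(c2ccccc2)C(=O)N2CCCCC(N3CCCC3)C12` is compound 3 with a much smaller group at the same position: one nitrogen atom in place of a group of 10 heavy atoms (8 carbon, 1 nitrogen, 1 oxygen; one six-membered aromatic ring of carbon only), on a double-bonded ring carbon

Going by the values given here, two measured steps touch this position. Swapping one large group for another of the same size gave a number 1.8 percentage points higher from compound 1 to compound 3 (within the scatter), so the exact make-up of a large group there seems to matter little. Replacing a smaller eight-atom group by the larger group of compound 3 gave a number 33.2 percentage points higher from compound 2 to compound 3 (beyond the scatter), and the partner step a number 31.4 percentage points lower from compound 1 to compound 2 (beyond the scatter) points the same way: the compound with the smaller group at this position was the weak one. Compound 4 goes further, keeping only a single nitrogen atom there. Among the compounds with values here, on this basis a drop beyond the scatter is expected, about a number 30.3 percentage points lower from compound 3 to compound 4 (beyond the scatter), though with only one comparison of this kind the range is wide. Compound 4 is therefore estimated at 45%, between 25% and 65%.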

Compound 4, a percentage reported as inhibition, in the whole organism at one dose (the size of the read-out at that dose, not a potency): 90.1%
Beside the measured number, compound 4's estimate is 45.1 percentage points below it; measured number above the stated range.
By their numbers in this assay, from the lowest: compound 2; then compounds 1 and 3 (each within the scatter of the next); then compound 4.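

At the double-bonded ring carbon, the plain amino group of compound 4 gives the highest number of the four in this assay: stripping away the large group gives a number 14.8 percentage points higher from compound 3 to compound 4 (beyond the scatter), while removing the chains on the amine nitrogen gives a number 16.6 percentage points higher from compound 1 to compound 4 (beyond the scatter) and a number 48 percentage points higher from compound 2 to compound 4 (beyond the scatter). Among these compounds, then, nothing added to this nitrogen improves on the bare amino group, and the earlier impression that a smaller group here goes with a weaker effect does not hold. Size alone does not order the series either: compound 4 has the smallest group and compound 2 a mid-sized one, yet they lie at opposite ends, with the larger groups of compounds 1 and 3 in between.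

Nothing measured here accounts for this order. On these data alone, it remains open whether a very small addition, such as a methyl or an acetyl group on the amine nitrogen, would keep the high number, and whether a hydroxyl group in place of the amino group would do the same.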